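A Larger Aromatic Group on the Amide Carbonyl

The source may report more compounds than this note shows. Statements on the series, on what has been measured and on what is new or still open speak of the compounds shown alone.

Three compounds share one core and differ only in the aromatic group attached to a carbonyl carbon. Compound 1 `Cc1ncccc1C(=O)NCCC1CCN(S(=O)(=O)NC(=O)NC[C@@H]2C[C@@H]3C=C[C@@H]2C3)CC1` gives 16% in a functional assay on the whole organism (blood) with Rattus norvegicus as the target, with stated times of 24 h and 1 h, at a dose of 5 mg/kg by the intraperitoneal route (on this read-out higher numbers stand for a stronger effect at the one dose given and lower numbers for a weaker effect), compound 2 `COc1ccncc1C(=O)NCCC1CCN(S(=O)(=O)NC(=O)NC[C@@H]2C[C@@H]3C=C[C@@H]2C3)CC1` gives 14%, and compound 3 `O=C(NC[C@@H]1C[C@@H]2C=C[C@@H]1C2)NS(=O)(=O)N1CCC(CCNC(=O)c2cc(Cl)ccn2)CC1` gives 32%, the highest of the three numbers. The steps of a number 16 percentage points higher from compound 1 to compound 3 (beyond the scatter) and a number 18 percentage points higher from compound 2 to compound 3 (beyond the scatter) were both beyond the scatter, while a number 2 percentage points lower from compound 1 to compound 2 (within the scatter) lay within it.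

Compound 4 `COc1ccc2nccc(C(=O)NCCC3CCN(S(=O)(=O)NC(=O)NC[C@@H]4C[C@@H]5C=C[C@@H]4C5)CC3)c2c1` is not yet measured. The change from compound 3 to compound 4 is 6-methoxyquinolin-4-yl in place of 4-chloropyridin-2-yl on a carbonyl carbon. Among the measured compounds shown here, two measured steps bear on it, because a number 16 percentage points higher from compound 1 to compound 3 (beyond the scatter) and a number 18 percentage points higher from compound 2 to compound 3 (beyond the scatter) also swapped the group on the same carbonyl carbon, and each was a modest rise into compound 3. For the measured compounds named here, no measured step shows how the entering group behaves, so the step of a number 10 percentage points lower from compound 3 to compound 4 (within the scatter) is expected to be a modest fall, with wide uncertainty. Compound 4 is therefore estimated at 22%, within a range from 8% to 40%.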

Compound 4, a percentage reported as activity, at one dose (the size of the read-out at that dose, not a potency): 10%
The estimate for compound 4 lay 12 percentage points above the measured number, within the range that was stated.
By their numbers in this assay, from the lowest: compounds 4, 2 and 1 (each within the scatter of the next); then compound 3.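

The swap on the carbonyl carbon gives a number 22 percentage points lower from compound 3 to compound 4 (beyond the scatter), so the higher number seen with 4-chloropyridin-2-yl does not carry over to the two-ring 6-methoxyquinolin-4-yl group. The other two comparisons, a number 4 percentage points lower from compound 2 to compound 4 (within the scatter) and a number 6 percentage points lower from compound 1 to compound 4 (within the scatter), show that the new group cannot be told apart from 4-methoxypyridin-3-yl or 2-methylpyridin-3-yl, which leaves compound 3 alone above the rest in this assay. Nothing measured here explains the fall.

Still open, on these data alone, is whether the fall goes with the second ring or with the methoxy group, a question that a plain quinolin-4-yl group would help to separate. Also open, as far as these compounds go, is how much of the number of compound 3 depends on the chlorine, which a plain pyridin-2-yl group would test.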